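The source may report more compounds than this note shows. Statements on the series, on what has been measured and on what is new or still open speak of the compounds shown alone.

Compound 1 `CC1=CC[C@@H]([C@@](C)(O)CCCC(C)(C)NC(=S)NN)CC1` is the smaller of the two measured compounds. In a functional assay on HT-29 cells (Homo sapiens) for cytotoxicity, read by sulforhodamine B assay (a higher number here means that more compound is tolerated, a lower number that less compound is tolerated), compound 1 gives > 100000 nM, which is a limit of the assay and not a number. Compound 2 `COc1ccc(/C=N\NC(=S)NC(C)(C)CCC[C@](C)(O)[C@@H]2CC=C(C)CC2)cc1` differs from compound 1 on an amide-type nitrogen. In this assay compound 2 gives > 100000 nM, again only a limit. The step that the two limits leave unreadable from compound 1 to compound 2 therefore cannot be read, and compound 2 stands at the limit of > 100000 nM in this assay, at which 2 of the 2 values shown sit. Compound 3 `CC1=CC[C@@H]([C@@](C)(O)CCCC(C)(C)NC(=S)N/N=C\c2ccc(O)cc2)CC1` differs from compound 2 by hydrogen in place of methyl on an oxygen on an aromatic ring, methoxy to hydroxy and 4-methoxyphenyl to 4-hydroxyphenyl. Going by the values given here, the only measured step that bears on this change is the one from compound 1 to compound 2, and its size is not readable, so no direction beyond the scatter is expected. Compound 3 is estimated at 100000 nM, between 40000 nM and 300000 nM, most likely as a further limit. The expected step of a number no higher from compound 2 to compound 3 (the limit leaves the size open) is accordingly none beyond the scatter.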

Compound 3, concentration lethal to 50% of the cells: 58500 nM
Beside the measured number, compound 3's estimate is 1.7-fold (0.23 log units) above it; the measured number falls inside the stated range.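

In this assay, going by these compounds alone, hydrogen in place of methyl on the oxygen on the aromatic ring, methoxy to hydroxy, brings the first value in the set that is a number and not a limit. The change reads as an at least 1.7-fold lower number from compound 2 to compound 3 (0.23 log units; that floor lies within the scatter), and the larger change on the amide-type nitrogen reads as an at least 1.7-fold lower number from compound 1 to compound 3 (0.23 log units; that floor lies within the scatter). Both are floors that lie within the scatter, so neither shows a real change, and the picture remains dominated by the assay limit: the limit of > 100000 nM in this assay, at which 2 of the 3 values shown sit.

As far as these compounds go, the true size of both steps stays open, since each starts from a limit. Also open, from the compounds shown here alone, is whether an amine or a carboxylic acid in place of the hydroxy of 4-hydroxyphenyl would move the value clearly beyond the scatter.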